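The compounds below may be only part of what the source reports. "The series", "measured", "known", "first", "only" and "open" are said of these compounds alone.

Going by the values given here, in a functional assay on MCF7 cells (Homo sapiens) for antiproliferative activity, read by MTT assay, with a stated time of 48 h (on this read-out lower numbers stand for stronger inhibition and higher numbers for weaker inhibition), compound 1 `O=C(/C=C/c1ccccn1)c1nc2ccccc2[nH]1` gives 3640 nM, and this is the only true number available so far. That makes it the sole numerical anchor for anything that follows, so it cannot yet be ranked against a series of measured values. In this assay, compound 2 `O=C(/C=C/c1cccc(Cl)c1)c1nc2ccccc2o1` is recorded only as a limit, > 100000 nM.

The compound still awaiting measurement is compound 3 `O=C(/C=C/c1cccnc1)c1nc2ccccc2[nH]1`, which has the same atoms as compound 1, joined differently: pyridin-3-yl in place of pyridin-2-yl on a double-bonded chain carbon bound to a double-bonded chain carbon. In words, pyridin-3-yl stands in place of pyridin-2-yl on a double-bonded chain carbon bound to a double-bonded chain carbon, and the rest of the molecule is unchanged.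

Among the compounds with values here, no two measured compounds here differ in one place, so the data offer no direct precedent for this change. With compound 1 at 3640 nM as the only reference, no direction can be favoured in this assay. The expected step, a 1.1-fold higher number from compound 1 to compound 3 (0.04 log units; within the scatter), is therefore none beyond the usual scatter, though the uncertainty is wide. The estimated value for compound 3 is 4000 nM, with an expected range from 1200 nM to 14000 nM.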

Compound 3, half-maximal inhibitory concentration: 21700 nM
Compound 3: the middle estimate sits 5.4-fold (0.73 log units) below what was measured; the whole stated range lies below it.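

Going by these compounds alone, the exchange of pyridin-2-yl for pyridin-3-yl on a double-bonded chain carbon bound to a double-bonded chain carbon gives, in this assay, a 6.0-fold higher number from compound 1 to compound 3 (0.78 log units; beyond the scatter) and is the first one-place comparison in this set. It shows that this place is sensitive to how the ring is joined: the two groups have the same heavy atoms and the same counts of donors and acceptors, yet inhibition is weaker with pyridin-3-yl. Within the data shown here, compound 3 still gives a true number, and the one value that is a limit and not a number belongs to compound 2: the limit of > 100000 nM in this assay, at which 1 of the 3 values shown sits.

As far as these compounds go, a single pair cannot tell why the step arises, so its cause stays open, as does whether it would hold on a different core. Also open, from the compounds shown here alone, is how pyridin-4-yl or an unsubstituted phenyl would compare at the same place, and so whether pyridin-2-yl is a favourable group here or compound 3 is merely a poor one.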